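Triazolylmethyl indole esters: aryl swap on the triazole nitrogen

The source may report more compounds than this note shows. Statements on the series, on what has been measured and on what is new or still open speak of the compounds shown alone.

Measured so far:
compound 1 `Cc1cccc(-n2cc(COC(=O)c3cc4ccccc4[nH]3)nn2)c1C` — 30300 nM
compound 2 `CCCCc1ccc(-n2cc(COC(=O)c3cc4ccccc4n3Cc3cn(-c4ccc(CCCC)cc4)nn3)nn2)cc1` — 42800 nM
compound 3 `Cc1cccc(-n2cc(COC(=O)c3cc4ccccc4n3Cc3cn(-c4cccc(C)c4C)nn3)nn2)c1C` — > 200000 nM

In a functional assay on HeLa cells (Homo sapiens) for cytotoxicity, read by MTT assay, with a stated time of 48 h (a higher number here means a weaker inhibitor, a lower number a stronger inhibitor), compound 1 gives 30300 nM. Compound 2 gives 42800 nM, a gap to compound 1 that sits within the scatter. For compound 3 this assay reports only a limit, (the limit of > 200000 nM in this assay, at which 1 of the 3 values shown sits), not a number.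

Compound 4 `COc1ccc(-n2cc(COC(=O)c3cc4ccccc4[nH]3)nn2)cc1` is not yet measured. It differs from compound 1 by 4-methoxyphenyl in place of 2,3-dimethylphenyl on an aromatic nitrogen. For the measured compounds named here, no measured pair shows this kind of change, so no step size can be read from the series. The expected step from compound 1 to compound 4 is a 1.0-fold lower number from compound 1 to compound 4 (0.00 log units; within the scatter), none beyond the scatter. Compound 4 is estimated at 30000 nM, between 10000 nM and 100000 nM.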

Compound 4, half-maximal inhibitory concentration: 16100 nM
Beside the measured number, compound 4's estimate is 1.9-fold (0.27 log units) above it, within the range that was stated.
By their numbers in this assay, from the lowest: compounds 4, 1 and 2 (each within the scatter of the next, the first and the last beyond it). At a limit, above all of these: compound 3.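

For the compounds shown here, exchanging 2,3-dimethylphenyl for 4-methoxyphenyl on the aromatic nitrogen gives the first step that can be read at this position in this assay: a 1.9-fold lower number from compound 1 to compound 4 (0.27 log units; within the scatter). This exchange brings in a hydrogen-bond acceptor with no change in heavy-atom count, and the number stays within the scatter. Nothing measured here accounts for the step.

Going by these compounds alone, the single pair does not separate the departure of the two methyl groups from the arrival of the methoxy group. Going by these compounds, whether an amine or a carboxylic acid on this aryl ring would move the number beyond the scatter remains open.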